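Intrinsic activity at the secretagogue receptor: phenyl to pyridin-4-yl

The compounds below may be only part of what the source reports. "The series", "measured", "known", "first", "only" and "open" are said of these compounds alone.

Measured so far:
compound 1 `CC(=O)c1ccc(N2C[C@@H](C)N[C@@H](C)C2)cc1NS(=O)(=O)c1ccc(-c2ccccn2)s1`: 0.9
compound 2 `COc1ccc(N2C[C@@H](C)N[C@@H](C)C2)cc1NS(=O)(=O)c1ccc(-c2ccccc2)cc1`: 1

In a functional assay for agonist activity at growth hormone secretagogue receptor type 1 (Homo sapiens), read by FLIPR (on this read-out higher numbers stand for larger maximal responses and lower numbers for smaller maximal responses), compound 2 gives 1, and compound 1 gives 0.9; the two numbers lie within the usual scatter of each other, so no order between them is claimed. Compound 3 `COc1ccc(N2C[C@@H](C)N[C@@H](C)C2)cc1NS(=O)(=O)c1ccc(-c2ccncc2)cc1` differs from compound 2 by one change: pyridin-4-yl in place of phenyl on an aromatic carbon. For the measured compounds named here, no measured pair in this assay shows the effect of such a change, so the expectation rests on compound 2 alone. The step from compound 2 to compound 3 is expected to be none beyond the scatter, a number 0.10 lower from compound 2 to compound 3 (within the scatter). For compound 3 the estimate in this assay is 0.9, expected to fall between 0.7 and 1.1.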

Compound 3, intrinsic activity: the largest response reached, as a fraction of the reference agonist's: 0.7
The estimate for compound 3 lay 0.20 above the measured number; the measured number falls inside the stated range.
By their numbers in this assay, from the lowest: compound 3; then compounds 1 and 2 (each within the scatter of the next).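

In this assay, for the compounds shown here, the change to pyridin-4-yl in place of phenyl, para to a large group, gives a number 0.30 lower from compound 2 to compound 3 (beyond the scatter) and is the only step read so far. The maximal response at this position therefore responds to a ring nitrogen, even with the heavy-atom count unchanged and one hydrogen-bond acceptor added. No measurement at hand accounts for the step.

Open, on these data alone, is whether a pyrimidin-5-yl ring or a phenyl bearing a carboxylic acid at this place would give a response like that of compound 2. A single pair also cannot show whether the step carries over to other cores.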